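This account rests on a few compounds, and the source may have more. Where it says the series, first, only, none or still open, it means among the compounds named here.

Compound 1 `Cc1cc(NC(=O)Cn2nnc(-c3ccccc3)n2)n(C2CCOCC2)n1` is the starting point. In an assay on HEK293 cells for activation of Kir3.1/Kir3.2 (Homo sapiens), read by thallium flux (on this read-out lower numbers stand for smaller maximal responses and higher numbers for larger maximal responses), compound 1 gives 115%, a full response. Compound 1 holds the only number shown here, while the other value shown is the limit of > 10% in this assay, at which 1 of the 2 values shown sits. Compound 2 `CC1(c2cc(NC(=O)Cn3nnc(-c4ccccc4)n3)n(C3CCCCC3)n2)CC1` gives > 10% in this assay, which is a limit of the assay rather than a number.

Compound 3 `Cc1cc(NC(=O)Cn2nnc(-c3ccccc3)n2)n(-c2ccccc2)n1` differs from compound 1 in one place: phenyl in place of oxan-4-yl on an aromatic nitrogen. Within the data shown here, no measured pair with a change of this kind is available, so the size of the step has to be guessed. The expectation is a step from compound 1 to compound 3 of a number 15 percentage points lower from compound 1 to compound 3 (beyond the scatter) in this assay, that is, no change beyond the usual scatter or a moderate loss. For compound 3 the estimated maximal response in this assay is 100%, with a range from 60% to 130%.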

Compound 3, largest response reached (Emax), in percent of the reference or control that the assay uses: 66%
Beside the measured number, compound 3's estimate is 34 percentage points above it, within the range that was stated.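

Among these compounds, this is the first measured change at the group on the aromatic nitrogen, and it shows that the maximal response depends on which six-membered ring sits there. In this assay, putting phenyl in place of oxan-4-yl gives a step of a number 49 percentage points lower from compound 1 to compound 3 (beyond the scatter), yet compound 3 still gives 66%, so the change lowers the maximal response without abolishing it. Nothing measured here accounts for a step of this size.

With only a few groups shown at this position, it remains open whether a piperidine ring bearing an amine, a pyridine ring or an open butyl chain would give a response closer to that of compound 1 or of compound 3. Also open, as far as these compounds go, is how a fluorine or methoxy group on the phenyl ring of compound 3 would shift the response.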